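This account rests on a few compounds, and the source may have more. Where it says the series, first, only, none or still open, it means among the compounds named here.

The measured compounds are:

Compound 1, `COCC(COc1nc(N2CCCCC2)c2nc(OCC(COC)OC)nc(N3CCCCC3)c2n1)OC`: 87%
Compound 2, `CCN(CC)c1nc(N2CCCCC2)c2nc(N(CC)CC)nc(N3CCCCC3)c2n1`: "not active" (no number reported)
Compound 3, `OCC(O)COc1nc(N2CCCCC2)c2nc(OC[C@@H](O)CO)nc(N3CCCCC3)c2n1`: 37%

In a functional assay on L1210 cells (Mus musculus) for inhibition, read by thymidine incorporation, tested at 10 uM (a higher number here means a stronger effect of the compound at the concentration tested, a lower number a weaker effect), compound 1 gives 87%, the higher of the two numbers reported. Compound 3 gives 37%, a gap to compound 1 that lies well beyond the usual scatter of this kind of measurement. Compound 2 was reported as not active, without a number, so it cannot be placed on the same scale.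

Compound 4, `COC[C@H](COc1nc(N2CCCCC2)c2nc(OC[C@H](COC)OC)nc(N3CCCCC3)c2n1)OC`, shares every atom and bond with compound 1; the difference is the two compounds have the same atoms and bonds; at least one stereo element is drawn with a configuration in one of them and without one in the other: 2 of 2 stereo elements differ; a stereocentre at a saturated chain carbon is drawn without a configuration in compound 1 and R in compound 4; a stereocentre at a saturated chain carbon is drawn without a configuration in compound 1 and S in compound 4. Compound 1 is thus drawn as the stereochemically undefined material, while compound 4 is one defined stereoisomer of it. Within the data shown here, no step between two measured compounds is available to show what defining these centres does here. The expectation for compound 4 is therefore a change of no size beyond the scatter, in no particular direction, and the estimated step of a number 2 percentage points lower from compound 1 to compound 4 (within the scatter) reflects that. Compound 4 is expected to give about 85%, with a likely range from 70% to 96%.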

Compound 4, a percentage reported as inhibition, at one concentration (the size of the read-out at that concentration, not a potency): 100%
The estimate for compound 4 lay 15 percentage points below the measured number, and the stated range ends below it.
By their numbers in this assay, from the lowest: compound 3; then compound 1; then compound 4.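

In this assay, drawing the two stereocentres at the saturated chain carbons with defined configurations, one R and one S, goes with a number 13 percentage points higher from compound 1 to compound 4 (beyond the scatter). Among these compounds, the earlier compounds held no pair that differed only in stereochemistry, so this is the first sign that the configuration at these side-chain carbons can be read in this assay, with the atoms and bonds unchanged. The only difference to which the step can be tied is this: the fact that one of compounds 1 and 4 is drawn with a defined configuration and the other without, at the place where they differ

The compounds shown do not tell how the other defined stereoisomers compare, so it stays open whether the step comes from one centre, from both, or from the pairing of the two. Nor do they show whether a longer chain, such as an ethyl ether in place of the methyl ethers, or a carboxylic acid on these side chains would keep the effect.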